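Trifluoromethylphenyl Isoxazole Variant in a Weak Series

The source may report more compounds than this note shows. Statements on the series, on what has been measured and on what is new or still open speak of the compounds shown alone.

compound 1 `Cc1ccc(-c2cc(COC3(C(F)(F)F)Oc4ccccc4C=C3C(=O)O)on2)cc1`: in a functional assay on DU-145 cells (Homo sapiens) for inhibition, read by MTT assay, with a stated time of 24 h (a lower number here means a stronger inhibitor, a higher number a weaker inhibitor), compound 1 gives 41400 nM
compound 2 `O=C(O)C1=Cc2ccccc2OC1(OCc1cc(-c2ccc3ccccc3c2)no1)C(F)(F)F`: in this assay compound 2 gives 141000 nM
compound 3 `O=C(O)C1=Cc2ccccc2OC1(OCc1cc(-c2ccc(F)cc2F)no1)C(F)(F)F`: in this assay compound 3 gives only the limit > 150000 nM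

Compound 3 thus stands at the weak end of the three, its value being a limit of the assay, namely (the limit of > 150000 nM in this assay, at which 1 of the 3 values shown sits). Compound 4 `O=C(O)C1=Cc2ccccc2OC1(OCc1cc(-c2cccc(C(F)(F)F)c2)no1)C(F)(F)F` differs from compound 3 by 3-(trifluoromethyl)phenyl in place of 2,4-difluorophenyl on an aromatic carbon. The measured aryl swaps bear on this change: a 3.4-fold higher number from compound 1 to compound 2 (0.53 log units; beyond the scatter) and an at least 3.6-fold higher number from compound 1 to compound 3 (0.55 log units; beyond the scatter) were modest, while an at least 1.0-fold higher number from compound 2 to compound 3 (0.02 log units; that floor lies within the scatter) lay within the scatter at the floor. A step of no clear size beyond the scatter is therefore expected in this assay, with another limit quite possible. Compound 4 is estimated at 150000 nM, between 50000 nM and 450000 nM. The expected step is a number no higher from compound 3 to compound 4 (the limit leaves the size open).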

Compound 4, half-maximal inhibitory concentration: 155000 nM
Compound 4: the middle estimate sits 1.0-fold (0.01 log units) below what was measured, within the range that was stated.
By their numbers in this assay, from the lowest: compound 1; then compounds 2 and 4 (each within the scatter of the next).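

At this position, a bulky naphthalen-2-yl group and a 3-(trifluoromethyl)phenyl group are not told apart, with a 1.1-fold higher number from compound 2 to compound 4 (0.04 log units; within the scatter). The new group also gives a 3.7-fold higher number from compound 1 to compound 4 (0.57 log units; beyond the scatter), so among the aryl groups shown, only the 4-methylphenyl group of compound 1 stands clearly apart, at the low end of the numbers in this assay. The step from compound 3 to compound 4 cannot be read, since compound 3 has only a limit: the limit of > 150000 nM in this assay, at which 1 of the 4 values shown sits.

As far as these compounds go, what an amine on the phenyl ring, or a longer chain in its place, would do at this position stays open. So does whether any group here could bring the number well below that of compound 1.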